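A few compounds are considered here, and "the series" means these few. Any claim that something is new, unique, unknown or untested is made for them only; others in the source may bear on it.

Of the compounds shown here, three have been tested in an assay on a protein complex for inhibition of CDK8/Cyclin C (Homo sapiens), with a stated time of 1 h, tested at 10 uM; a higher number here means more inhibition at the concentration tested (going by the name of the read-out), a lower number less inhibition. Compound 2 `O=C(O)/C=C/c1ccncc1-c1ccc2ccccc2c1` gives 102%. Compound 1 `CNC(=O)/C=C/c1ccncc1-c1ccc2ccccc2c1` differs from compound 2 by methylamino in place of hydroxy on a carbonyl carbon; in this assay compound 1 gives 101%, and the step is a number 1 percentage points lower from compound 2 to compound 1 (within the scatter). Compound 3 `Cn1ccc2cc(-c3cnccc3/C=C/C(=O)O)ccc21` gives 102% in this assay; how its core differs from the core of compound 2 is not broken down here. Compound 4 `CNC(=O)/C=C/c1ccncc1-c1ccc2c(ccn2C)c1` differs from compound 3 by methylamino in place of hydroxy on a carbonyl carbon, the same change that turns compound 2 into compound 1, and the place of the change reads alike in both pairs. Compound 4 is expected to show a step of a number 2 percentage points lower from compound 3 to compound 4 (within the scatter) in this assay, resting on compound 1 having held the level of compound 2 through a number 1 percentage points lower from compound 2 to compound 1 (within the scatter). Compound 4 is accordingly estimated at 100%, with an expected span from 90% to 108%.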

Compound 4, a percentage reported as inhibition, at one concentration (the size of the read-out at that concentration, not a potency): 99%
Estimate against measurement, compound 4: 1 percentage points above; the range from low to high includes it.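

In this assay, methylamino in place of hydroxy on a carbonyl carbon gives a number 3 percentage points lower from compound 3 to compound 4 (within the scatter). Set beside the earlier pair, the change reads alike on the two cores: the same change on two cores in this assay, a number 1 percentage points lower (within the scatter) from compound 2 to compound 1 and a number 3 percentage points lower (within the scatter) from compound 3 to compound 4, 2 percentage points apart, within the scatter of two such steps. This shows that, at this one concentration, the change carried from one core to the other with no difference beyond the scatter, but a percentage at a single concentration is not a potency, so it does not show that the two cores would respond alike in potency, and two pairs make no rule for other cores.

The compounds shown leave open how an ethylamino or a dimethylamino group would read on the same carbonyl carbon. They also leave open whether the change would read alike on any further core.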